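Amide nitrogen substitution in a diaryl thiourea series

The source may report more compounds than this note shows. Statements on the series, on what has been measured and on what is new or still open speak of the compounds shown alone.

Of the compounds shown here, two have been measured in a functional assay on PC-3 cells (Homo sapiens) for cytotoxicity, read by MTT assay, with a stated time of 48 h; a higher number here means a weaker inhibitor, a lower number a stronger inhibitor. Compound 1 `CNC(=O)c1cc(Oc2cccc(NC(=S)Nc3ccc(F)c(F)c3)c2)ccn1` gives 33100 nM; compound 2 `O=C(NC1CCCCC1)c1cc(Oc2cccc(NC(=S)Nc3ccc(F)c(F)c3)c2)ccn1` gives 8100 nM. Among the compounds with values here, the one measured step, a 4.1-fold lower number from compound 1 to compound 2 (0.61 log units; beyond the scatter), shows that a larger group on the amide-type nitrogen lowers the number. Within the data shown here, compound 2 thus stands lowest of the two values in this assay, with compound 1 as its only neighbour.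

Compound 3 `O=C(c1cc(Oc2cccc(NC(=S)Nc3ccc(F)c(F)c3)c2)ccn1)N1CCCC1` differs from compound 2 by pyrrolidin-1-yl in place of cyclohexylamino on a carbonyl carbon. Among the measured compounds shown here, only the step from compound 1 to compound 2 bears on this change, and it does so indirectly: the group entering is smaller than the one leaving and carries no hydrogen-bond donor. A modest rise in the number is therefore expected for compound 3 in this assay, roughly a 1.9-fold higher number from compound 2 to compound 3 (0.27 log units; within the scatter), but with wide uncertainty since no tertiary amide has been measured. The estimate for compound 3 is 15000 nM, within 5000 nM to 45000 nM.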

Compound 3, half-maximal inhibitory concentration: 45600 nM
For compound 3 the middle estimate is 3.0-fold (0.48 log units) below the measured one; measured number outside the range, above it.
By their numbers in this assay, from the lowest: compound 2; then compounds 1 and 3 (each within the scatter of the next).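

In this assay, the lower number of compound 2 is not a general result of placing a ring on this carbonyl carbon: a 5.6-fold higher number from compound 2 to compound 3 (0.75 log units; beyond the scatter) with pyrrolidin-1-yl in place of cyclohexylamino. Pyrrolidin-1-yl in place of methylamino gives a 1.4-fold higher number from compound 1 to compound 3 (0.14 log units; within the scatter), so compound 3 cannot be told apart from compound 1, and of the three groups only cyclohexylamino stands apart. No evidence on the origin of this difference is available.

Compound 2 and compound 3 differ both in ring size and in the amide hydrogen, so the change does not show which of the two matters, or whether both do. Cyclopentylamino and piperidin-1-yl on the same carbonyl carbon would separate these two differences.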